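The source may hold more compounds than are shown below. What is called first, only, known or untested is meant among the compounds shown, and "the series" means these compounds.

Measured compounds and their values:

Compound 1, `Cc1ccccc1/C(CCN1CCN(c2ccccn2)CC1)=N/O`: 82%
Compound 2, `O/N=C(\CCN1CCN(c2ccccn2)CC1)c1ccc(F)cc1`: 74%
Compound 3, `O/N=C(\CCN1CCN(c2ccccn2)CC1)c1ccc(F)cc1F`: 78%

These three compounds share the same core and differ only in the aromatic group sitting on the carbon that carries a double bond to nitrogen. In a functional assay on HEK293 cells with D(4) dopamine receptor (Homo sapiens) as the target, read by FLIPR (on this read-out lower numbers stand for smaller maximal responses and higher numbers for larger maximal responses), compound 1 gives 82%, compound 2 gives 74% and compound 3 gives 78%. Compound 3 stands second highest of the three numbers, but the steps that reach it stay within the scatter: a number 4 percentage points lower from compound 1 to compound 3 (within the scatter) and a number 4 percentage points higher from compound 2 to compound 3 (within the scatter). The remaining step, a number 8 percentage points lower from compound 1 to compound 2 (within the scatter), is likewise within the scatter.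

Compound 4, `Cc1ccc(O)c(/C(CCN2CCN(c3ccccn3)CC2)=N/O)c1`, has not yet been measured. Its difference from compound 3 is 2-hydroxy-5-methylphenyl in place of 2,4-difluorophenyl on a carbon with a double bond to nitrogen. Every measured step that changes the aromatic group in this position has moved the maximal response by less than the scatter, so a step beyond the scatter is not expected here either; the expected step is no change at the digits printed from compound 3 to compound 4 (within the scatter). Compound 4 is therefore estimated to give 78% in this assay, with a range from 64% to 92%.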

Compound 4, largest response reached (reported as efficacy), in percent of the reference or control that the assay uses: 73%
Beside the measured number, compound 4's estimate is 5 percentage points above it, and the stated range covers the measured number.
By their numbers in this assay, from the lowest: compounds 4, 2, 3 and 1 (each within the scatter of the next).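

Putting 2-hydroxy-5-methylphenyl in place of the earlier aromatic groups gives a number 5 percentage points lower from compound 3 to compound 4 (within the scatter), a number 1 percentage points lower from compound 2 to compound 4 (within the scatter) and a number 9 percentage points lower from compound 1 to compound 4 (within the scatter). Unlike 2,4-difluorophenyl, the entering group carries a hydrogen-bond donor and a hydrogen-bond acceptor, yet in this assay this exchange on a carbon with a double bond to nitrogen gives no step beyond the scatter, so the flat picture now extends to a hydroxy-bearing ring. Nothing available here explains why the maximal response stays within the scatter across these groups.

On these data alone, all four groups are aromatic rings of carbon only, so it remains open whether the same holds for a ring bearing an amine or a carboxylic acid, or for a non-aromatic group such as cyclohexyl. Compound 4 also brings its hydroxy and methyl groups together, which leaves the contribution of each alone unresolved.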